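From methoxy to butoxy: a step with no measured guide

The source may hold more compounds than are shown below. What is called first, only, known or untested is meant among the compounds shown, and "the series" means these compounds.

Of the compounds shown here, two have been tested so far, and neither gives a number. In an ADME assay on RAW264.7 cells (Mus musculus) for cytotoxicity, read by MTT assay, with a stated time of 24 h, in the presence of a further agent that is not named here (a lower number here means a stronger inhibitor, a higher number a weaker inhibitor), compound 1 `O=C1OC(Cc2nc(Cc3ccccc3)no2)c2ccccc21` gives > 40000 nM, which is a limit of the assay and not a number. Compound 2 `COc1ccc(C(O)C2OC(=O)c3c(OC)cc(OC)cc32)cc1` gives > 40000 nM, which is also a limit. Compound 3 `CCCCOc1ccc(C(O)C2OC(=O)c3c(OC)cc(OC)cc32)cc1` changes compound 2 in one place: propyl in place of hydrogen on a saturated chain carbon bound to an oxygen on an aromatic ring. In words, this is propyl in place of hydrogen on a saturated chain carbon bound to an oxygen on an aromatic ring, turning methoxy into butoxy. Within the data shown here, no measured pair shows what this change does, so the expectation is loose. It rests on compound 2 at > 40000 nM. The expected step of a number no higher from compound 2 to compound 3 (the limit leaves the size open) is none beyond the usual scatter, and another limit is quite likely. For compound 3 the estimated value in this assay is 40000 nM, with an expected range of 15000 nM to 100000 nM.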

Compound 3, half-maximal inhibitory concentration: > 40000 nM
Compound 3 ended at the assay's limit; the forecaster's own chance of this, stated with the estimate: 70%; the middle value lies on the limit itself.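

Among these compounds, compound 2 and compound 3 both end at a limit of the assay, not at a number, so no step from methoxy to butoxy can be read between them: the limit of > 40000 nM in this assay, at which 3 of the 3 values shown sit. The compounds shown leave open whether that change has any effect in this assay.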